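Methoxy additions and cytotoxicity in a small series

A few compounds are considered here, and "the series" means these few. Any claim that something is new, unique, unknown or untested is made for them only; others in the source may bear on it.

Measured compounds:
compound 1, `COC(=O)/C(=C\c1ccc(OC(=O)c2ccccc2OC)cc1)Sc1ccnc2cc(Cl)ccc12`, gives 44700 nM in a functional assay on Jurkat E6.1 cells (Homo sapiens) for cytotoxicity, read by MTT assay, with a stated time of 24 h; on this read-out lower numbers stand for stronger inhibition and higher numbers for weaker inhibition
compound 2, `COC(=O)/C(=C\c1ccc(OC(=O)c2ccc(OC)cc2OC)cc1)Sc1ccnc2cc(Cl)ccc12`, gives 10200 nM
compound 3, `COC(=O)/C(=C\c1ccc(OC(=O)c2cccc(OC)c2OC)cc1)Sc1ccnc2cc(Cl)ccc12`, gives 25800 nM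

Compound 3 stands second highest of the three numbers: a 1.7-fold lower number from compound 1 to compound 3 (0.24 log units; within the scatter) lies within the scatter, while a 2.5-fold higher number from compound 2 to compound 3 (0.40 log units; beyond the scatter) lies beyond it. Compound 4, `COC(=O)/C(=C\c1ccc(OC(=O)c2cc(OC)cc(OC)c2OC)cc1)Sc1ccnc2cc(Cl)ccc12`, differs from compound 3 by methoxy in place of hydrogen on an aromatic carbon, the entering group sitting meta to a large group, meta to a methoxy group and para to a methoxy group. Two earlier methoxy additions on the same ring bear on this step: a 4.4-fold lower number from compound 1 to compound 2 (0.64 log units; beyond the scatter) and a 1.7-fold lower number from compound 1 to compound 3 (0.24 log units; within the scatter). One was modest, the other within the scatter, so the outcome varies with the position. A modest lowering is expected, a 1.7-fold lower number from compound 3 to compound 4 (0.24 log units; within the scatter). Compound 4 is estimated at 15000 nM, with a range from 5000 nM to 40000 nM.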

Compound 4, half-maximal inhibitory concentration: 15600 nM
Compound 4: the middle estimate sits 1.0-fold (0.02 log units) below what was measured; measured number inside the range.
By their numbers in this assay, from the lowest: compounds 2, 4, 3 and 1 (each within the scatter of the next, the first and the last beyond it).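

Methoxy entering the 2,3-dimethoxyphenyl ring, meta to a large group, meta to a methoxy group and para to a methoxy group, gives a 1.7-fold lower number from compound 3 to compound 4 (0.22 log units; within the scatter), so a third methoxy on this ring yields no step that can be told from the scatter. The 2,3,5-trimethoxyphenyl group is not separated from the 2,4-dimethoxyphenyl group, with a 1.5-fold higher number from compound 2 to compound 4 (0.18 log units; within the scatter), but it is separated from the 2-methoxyphenyl group, with a 2.9-fold lower number from compound 1 to compound 4 (0.46 log units; beyond the scatter). The two methoxy steps also cannot be told apart: the same change on two cores in this assay, a 4.4-fold lower number (0.64 log units; beyond the scatter) from compound 1 to compound 2 and a 1.7-fold lower number (0.22 log units; within the scatter) from compound 3 to compound 4, 2.6-fold (0.42 log units) apart, within the scatter of two such steps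

From the compounds shown here alone, whether a hydroxy group or an amine at this place would read like methoxy remains open. So does whether a chloro group there would give a step beyond the scatter.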